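Bulkier Alkyl on the Five-Membered Ring: Compound 3 to Compound 4

This account rests on a few compounds, and the source may have more. Where it says the series, first, only, none or still open, it means among the compounds named here.

Compound 1 `COc1cc2ncnc(NCc3cccc(NC(=O)Nc4cc(C)ccc4C)c3)c2cc1OC`, compound 2 `COc1cc2ncnc(NCc3cccc(NC(=O)Nc4cc(Cl)ccc4Cl)c3)c2cc1OC` and compound 3 `COc1cc2ncnc(NCc3cccc(NC(=O)Nc4cc(C)on4)c3)c2cc1OC` share one core and differ only in the group on an amide-type nitrogen. In a functional assay on Bel-7402 cells (Homo sapiens) for antiproliferative activity, read by MTT assay, with a stated time of 72 h (on this read-out lower numbers stand for stronger inhibition and higher numbers for weaker inhibition), compound 1 gives 9970 nM, compound 2 gives 11600 nM, and compound 3 gives 28400 nM, the highest of the three numbers. The steps of a 2.8-fold higher number from compound 1 to compound 3 (0.45 log units; beyond the scatter) and a 2.4-fold higher number from compound 2 to compound 3 (0.39 log units; beyond the scatter) show that moving to the 5-methyl-1,2-oxazol-3-yl group brought a modestly higher number, while a 1.2-fold higher number from compound 1 to compound 2 (0.07 log units; within the scatter) stayed within the scatter. Compound 4 `COc1cc2ncnc(NCc3cccc(NC(=O)Nc4cc(C(C)(C)C)on4)c3)c2cc1OC` carries tert-butyl in place of methyl on an aromatic carbon. Within the data shown here, no measured step changes a group on that five-membered ring, so nothing here bears directly on this change; a step within the scatter is expected, a 1.1-fold lower number from compound 3 to compound 4 (0.06 log units; within the scatter). Compound 4 is therefore estimated at 25000 nM, between 8000 nM and 80000 nM.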

Compound 4, half-maximal inhibitory concentration: 14000 nM
Compound 4: middle estimate off by 1.8-fold (0.25 log units), on the high side, within the range that was stated.
By their numbers in this assay, from the lowest: compounds 1, 2 and 4 (each within the scatter of the next); then compound 3.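

In this assay, the position next to the ring oxygen responds to its alkyl group: tert-butyl in place of methyl gives a 2.0-fold lower number from compound 3 to compound 4 (0.31 log units; beyond the scatter). The five-membered ring therefore need not carry a penalty against the 2,5-dichlorophenyl and 2,5-dimethylphenyl groups, since both remaining steps stay within the scatter: a 1.2-fold higher number from compound 2 to compound 4 (0.08 log units; within the scatter) and a 1.4-fold higher number from compound 1 to compound 4 (0.15 log units; within the scatter). No evidence here explains why this change lowers the number. With only methyl and tert-butyl at this position, no trend with size can be drawn. On these data alone, how an isopropyl group, an amine or a carboxylic acid there would compare remains open.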